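Replacing the hydroxyphenyl with a furan ring

A few compounds are considered here, and "the series" means these few. Any claim that something is new, unique, unknown or untested is made for them only; others in the source may bear on it.

compound 1 `O=C(N/N=C/c1ccccc1O)c1cc(-c2ccccc2)nn1Cc1ccc(Cl)nc1` — 440 nM
compound 2 `COc1ccc(-c2cc(C(=O)N/N=C/c3ccccc3O)n(Cc3ccc(Cl)nc3)n2)cc1` — 570 nM

Of the compounds shown here, two have so far been measured in a physicochemical assay on A549 cells for solubility, read by microscopy, with a stated time of 24 h; on this read-out higher numbers stand for weaker inhibition and lower numbers for stronger inhibition. Going by the values given here, compound 1 gives 440 nM and compound 2 gives 570 nM; the single measured step, a 1.3-fold higher number from compound 1 to compound 2 (0.11 log units; within the scatter), shows that the methoxy in place of hydrogen on an aromatic carbon made no difference beyond the scatter. Compound 2 holds the higher of the two numbers, but its gap to compound 1 is within the scatter, so the two stand level.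

Compound 3 `COc1ccc(-c2cc(C(=O)N/N=C/c3ccco3)n(Cc3ccc(Cl)nc3)n2)cc1` has not yet been measured. It differs from compound 2 only in furan-2-yl in place of 2-hydroxyphenyl on a carbon with a double bond to nitrogen. Among the compounds with values here, no measured step touches this part of the molecule: the one step in hand concerns a distant aromatic carbon and was flat. The change removes a hydrogen-bond donor, and nothing in the measured pair says what that costs or gains. The author therefore expects a modest weakening at most, with wide uncertainty, the step of a 1.8-fold higher number from compound 2 to compound 3 (0.24 log units; within the scatter) being the estimate. Compound 3 is estimated at 1000 nM, within a range of 350 nM to 3000 nM.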

Compound 3, half-maximal inhibitory concentration: 15800 nM
Estimate against measurement, compound 3: 16-fold (1.20 log units) below; the measured number lies above the stated range.
By their numbers in this assay, from the lowest: compounds 1 and 2 (each within the scatter of the next); then compound 3.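

The carbon with a double bond to nitrogen proves to be a sensitive place in this series: in this assay, furan-2-yl in place of 2-hydroxyphenyl gives a 28-fold higher number from compound 2 to compound 3 (1.44 log units; beyond the scatter) and so a large loss of inhibition. The earlier methoxy change on an aromatic carbon gave only a 1.3-fold higher number from compound 1 to compound 2 (0.11 log units; within the scatter) and said nothing about this place, whereas this result shows that 2-hydroxyphenyl cannot be exchanged for furan-2-yl without a heavy cost in this assay. No measurement here gives a reason for the size of this step.

The exchange alters several things at once, going from a six-membered aromatic ring of carbon only to a five-membered aromatic ring with 1 hetero atom, and from 1 hydrogen-bond donor to 0 hydrogen-bond donors, so this single pair cannot tell which of these differences matters. From the compounds shown here alone, whether a plain phenyl or a pyridine ring on this carbon would keep the inhibition seen with compound 2, or would fall as far as compound 3, stays open.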